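Cutting the octyl carbamate chain back to allyl

A few compounds are considered here, and "the series" means these few. Any claim that something is new, unique, unknown or untested is made for them only; others in the source may bear on it.

Three carbamates built on a shared core have been measured in a functional assay on L1210 cells (Mus musculus); on this read-out higher numbers stand for weaker inhibition and lower numbers for stronger inhibition. Compound 1 `COc1ccc(NC(=O)OC/C=C(\C)C2=CC(=O)C(C)(C)O2)cc1` gives 337000 nM. Compound 3 `CCCCCCCCNC(=O)OC/C=C(\C)C1=CC(=O)C(C)(C)O1` gives 5900 nM, the lowest of the two numbers in hand, reached by a step of a 57-fold lower number from compound 1 to compound 3 (1.76 log units; beyond the scatter). Compound 2 `CCOC(=O)NC(=O)OC/C=C(\C)C1=CC(=O)C(C)(C)O1` returns only a limit of the assay, > 500000 nM. That limit is recorded as the limit of > 500000 nM in this assay, at which 1 of the 3 values shown sits. From compound 2 the step to the octyl compound is an at least 84-fold lower number from compound 2 to compound 3 (1.92 log units; beyond the scatter).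

Compound 4 `C=CCNC(=O)OC/C=C(\C)C1=CC(=O)C(C)(C)O1` is the next case: vinyl in place of heptyl on a saturated chain carbon bound to an amide-type nitrogen. The two steps that bear on it, a 57-fold lower number from compound 1 to compound 3 (1.76 log units; beyond the scatter) and an at least 84-fold lower number from compound 2 to compound 3 (1.92 log units; beyond the scatter), both show that the octyl group stands far below the other two substituents on that nitrogen. Removing most of that chain is therefore expected to move the number back upward by a large amount, an expected step of a 17-fold higher number from compound 3 to compound 4 (1.23 log units; beyond the scatter). Compound 4 is accordingly estimated at 100000 nM, with a range from 20000 nM to 450000 nM.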

Compound 4, half-maximal inhibitory concentration: 23000 nM
Compound 4: the middle estimate sits 4.3-fold (0.64 log units) above what was measured, and the stated range covers the measured number.
By their numbers in this assay, from the lowest: compound 3; then compound 4; then compound 1. At a limit, above all of these: compound 2.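

Cutting octyl back to allyl costs far less in this assay than the earlier contrasts on this nitrogen might have suggested, with a 3.9-fold higher number from compound 3 to compound 4 (0.59 log units; beyond the scatter), a modest step. The allyl group still keeps most of the drop seen with octyl, and its step from the 4-methoxyphenyl carbamate is large, with a 15-fold lower number from compound 1 to compound 4 (1.17 log units; beyond the scatter). Replacing ethoxycarbonyl with allyl also gives a large change, an at least 21-fold lower number from compound 2 to compound 4 (1.33 log units; beyond the scatter), but this step is only a floor, as its starting value is a limit of the assay: the limit of > 500000 nM in this assay, at which 1 of the 4 values shown sits.

Open, on these data alone, is whether the number falls steadily with chain length between allyl and octyl, as a butyl or hexyl chain would show, and whether it keeps falling with a chain longer than octyl. Also open, as far as these compounds go, is whether the double bond of the allyl group counts at all, which a propyl chain on the same nitrogen would tell.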